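A few compounds are considered here, and "the series" means these few. Any claim that something is new, unique, unknown or untested is made for them only; others in the source may bear on it.

Compound 2 `Cc1cc(C)cc(Cn2c(SCC(=O)Nc3ccccc3[N+](=O)[O-])nc3ccccc32)c1` gives 194000 nM in an ADME assay on MT4 cells (Homo sapiens) for cytotoxicity; on this read-out higher numbers stand for lower toxicity in this test and lower numbers for higher toxicity in this test. Within the data shown here, of the two numbers known so far, this is numerically the larger, but compound 1 `Cc1cc(C)cc(S(=O)(=O)n2c(SCC(=O)Nc3ccccc3Cl)nc3ccccc32)c1` gives 107000 nM in this assay, and the two values lie within the usual scatter of each other, so they show no real difference. Compound 3 `Cc1cc(C)cc(S(=O)(=O)n2c(SCC(=O)Nc3ccccc3[N+](=O)[O-])nc3ccccc32)c1` has not yet been tested. It differs from compound 2 in one place: (3,5-dimethylphenyl)sulfonyl in place of 3,5-dimethylbenzyl on an aromatic nitrogen. Compound 1 already carries that sulfonyl group and gives 107000 nM. On that basis the expected step is a 1.5-fold lower number from compound 2 to compound 3 (0.17 log units; within the scatter), nothing beyond the scatter. Compound 3 is expected to give 130000 nM, between 50000 nM and 320000 nM.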

Compound 3, half-maximal cytotoxic concentration: >= 26000 nM
Compound 3 ended at the assay's limit; the forecaster's own chance of this, stated with the estimate: 20%; the middle value is on the limit's open side.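

In this assay compound 3 gives >= 26000 nM, which is a limit and not a number. Its steps from compound 1 and compound 2 therefore cannot be read. From the compounds shown here alone, whether either swap, sulfonyl for benzyl or nitro for chloro, changes toxicity in these cells stays open.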